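This account rests on a few compounds, and the source may have more. Where it says the series, first, only, none or still open, it means among the compounds named here.

Compound 2, `O=S(=O)(c1cccc(F)c1)c1cnc2cc(F)ccc2c1-c1ccc(Cl)cc1`: 0.98 mL/min
Compound 3, `O=S(=O)(c1ccc(F)cc1)c1cnc2cc(F)ccc2c1-c1ccc(Cl)cc1`: 1.23 mL/min
Compound 1, `COc1ccc(-c2c(S(=O)(=O)c3cccc(F)c3)cnc3cc(F)ccc23)cc1`: 1.89 mL/min

All three were run in an ADME assay on microsomes from liver (Homo sapiens) for metabolic stability, tested at 2.5 uM; on this read-out lower numbers stand for slow clearance and higher numbers for fast clearance. On these numbers compound 2 sits at 0.98 mL/min, with compound 3 and compound 1 near it: a 1.3-fold higher number from compound 2 to compound 3 (0.10 log units; within the scatter), and a 1.9-fold lower number from compound 1 to compound 2 (0.29 log units; within the scatter). Neither gap reaches beyond the scatter, so the three compounds are, for practical purposes, indistinguishable in this assay.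

The next compound, compound 4, `O=S(=O)(c1cccc(F)c1)c1cnc2cc(F)ccc2c1-c1cccc(F)c1`, has not yet been measured. It differs from compound 2 in one place: 3-fluorophenyl in place of 4-chlorophenyl on an aromatic carbon. Among the measured compounds shown here, the measured step that bears most directly on it is the one from compound 1 to compound 2, which also changes the group on that same aromatic carbon and gave a 1.9-fold lower number from compound 1 to compound 2 (0.29 log units; within the scatter). The step from compound 2 to compound 3 alters a different part of the molecule and gave a 1.3-fold higher number from compound 2 to compound 3 (0.10 log units; within the scatter). Both changes to the shared core left this assay essentially unmoved, so a swap of one halogenated phenyl for another at the same position is expected to do the same: no step beyond the scatter in either direction.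

For compound 4 the estimate is 1.2 mL/min, with a likely range from 0.6 mL/min to 2.4 mL/min, which corresponds to an expected 1.2-fold higher number from compound 2 to compound 4 (0.09 log units; within the scatter).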

Compound 4, intrinsic clearance in a liver preparation (reported as CLH), per the amount of preparation that the assay uses: 0.24 mL/min
The estimate for compound 4 lay 5.0-fold (0.70 log units) above the measured number, outside the stated range (below it).
By their numbers in this assay, from the lowest: compound 4; then compounds 2, 3 and 1 (each within the scatter of the next).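

The group on this aromatic carbon, opposite the ring nitrogen, can move the number in this assay after all: 3-fluorophenyl in place of 4-chlorophenyl gives a 4.1-fold lower number from compound 2 to compound 4 (0.61 log units; beyond the scatter) and 3-fluorophenyl in place of 4-methoxyphenyl gives a 7.9-fold lower number from compound 1 to compound 4 (0.90 log units; beyond the scatter) and both steps lie beyond the scatter, while the earlier step at this carbon stayed within it. Two groups that look alike when counted can therefore read differently here, since each has 7 heavy atoms and one six-membered aromatic ring of carbon only, and they differ in the halogen and in where it sits on that ring. Nothing available here explains why the number falls with this change.

The step changes the halogen and its place on the ring together, so the compounds shown cannot tell which of the two goes with the lower number, and a 4-fluorophenyl or a 3-chlorophenyl on this carbon would separate them. Going by these compounds, how a group of another kind at the same carbon, such as an amine or a carboxylic acid, would read in this assay also stays open.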